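The compounds below may be only part of what the source reports. "The series", "measured", "known", "first", "only" and "open" are said of these compounds alone.

Measured compounds in a functional assay on HCT-116 cells (Homo sapiens) for cytotoxicity, read by MTT assay, with a stated time of 72 h; on this read-out lower numbers stand for stronger inhibition and higher numbers for weaker inhibition:
- compound 1 `COc1cccc(CNC(=O)c2nc(Br)c3cccnc3c2N[C@H]2CC[C@H](N)CC2)c1`: 6000 nM
- compound 2 `COC(=O)CNc1c(C(=O)NCc2ccc(F)cc2)nc(Br)c2cccnc12`: > 10000 nM
- compound 3 `CS(=O)(=O)NCCCCCCN(c1nc(C(=O)NCc2ccc(F)cc2)c(O)c2ncccc12)S(C)(=O)=O`: 3000 nM

The value of compound 2 is a limit of the assay, not a number, as the limit of > 10000 nM in this assay, at which 1 of the 3 values shown sits, records. That leaves two numbers: compound 1 sits alongside compound 3, with the two values lying within the usual scatter of each other, so neither can be called the stronger of the pair. For the measured compounds named here, no pair of measured compounds differs in a single place, so no measured step can anchor a prediction.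

Compound 4 `N[C@H]1CC[C@H](Nc2c(C(=O)Nc3ccccc3)nc(Br)c3cccnc23)CC1` is not yet measured. It differs from compound 1 in one place: phenyl in place of 3-methoxybenzyl on an amide-type nitrogen. Without any measured step to lean on, the expectation for this change is a small shift of roughly the size of the scatter, leaning towards a weaker number rather than a stronger one. The estimated step from compound 1 to compound 4 in this assay is a 1.3-fold higher number from compound 1 to compound 4 (0.12 log units; within the scatter). Compound 4 is therefore expected to give about 8000 nM, within a range from 2500 nM to 25000 nM.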

Compound 4, half-maximal inhibitory concentration: 2000 nM
Compound 4: middle estimate off by 4.0-fold (0.60 log units), on the high side, outside the stated range (below it).
By their numbers in this assay, from the lowest: compounds 4, 3 and 1 (each within the scatter of the next, the first and the last beyond it). At a limit, above all of these: compound 2.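

In this assay, for the compounds shown here, this is the first change at a single place that can be read, and it shows that the group on the amide-type nitrogen affects the result: phenyl in place of 3-methoxybenzyl gives a 3.0-fold lower number from compound 1 to compound 4 (0.48 log units; beyond the scatter). The step is modest but beyond the scatter, and the smaller group is enough for it, so the full 3-methoxybenzyl is not needed for activity in this series. The swap removes the methoxy group and the benzyl carbon together, and nothing measured here gives a reason for the step.

Which of those two losses matters stays open; a plain benzyl or a 3-methoxyphenyl on the same nitrogen would separate them. One step also cannot show whether the same swap would act alike with another group elsewhere on the shared core.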